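Urea amine swap on the shared core: compound 3

The source may report more compounds than this note shows. Statements on the series, on what has been measured and on what is new or still open speak of the compounds shown alone.

Measured so far, in an assay on IM-9 cells for binding affinity to Substance-P receptor (Homo sapiens); a higher number here means a weaker inhibitor, a lower number a stronger inhibitor:
compound 1 `CN(Cc1ccccc1Cl)C(=O)Nc1c(-c2ccc(F)cc2)c2ccccc2c(=O)n1C` gives 480 nM
compound 2 `Cc1cc2c(-c3ccccc3)c(NC(=O)N(C)Cc3ccccc3)n(C)c(=O)c2cc1C` gives 16 nM

Compound 2 stands lowest of the two in this assay; compound 1 sits higher by a margin beyond the usual scatter, but the two differ in several places, so no single step can be read from that pair.

Compound 3 `Cc1cccc(NC(=O)Nc2c(-c3ccccc3)c3cc(C)c(C)cc3c(=O)n2C)c1` differs from compound 2 in one place: (3-methylphenyl)amino in place of benzyl(methyl)amino on a carbonyl carbon. For the measured compounds named here, no measured pair isolates this change. The step from compound 2 to compound 3 in this assay is expected to be a moderate loss, a 6.3-fold higher number from compound 2 to compound 3 (0.80 log units; beyond the scatter). Compound 3 is expected to give 100 nM, within 20 nM to 600 nM.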

Compound 3, half-maximal inhibitory concentration: 840 nM
Compound 3: the middle estimate sits 8.4-fold (0.92 log units) below what was measured; measured number outside the range, above it.
By their numbers in this assay, from the lowest: compound 2; then compounds 1 and 3 (each within the scatter of the next).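

For the compounds shown here, the group on this carbonyl carbon matters on the shared core: a 53-fold higher number from compound 2 to compound 3 (1.72 log units; beyond the scatter) in this assay is the first single-place reading, and it is a large loss. The change both adds a hydrogen-bond donor and replaces benzyl(methyl)amino with a directly attached aromatic amine, and this one step cannot separate those two features. No measurement on hand accounts for the size of the loss.

Open, from the compounds shown here alone, is how benzylamino or methyl(phenyl)amino would read on the same core, as either would vary those features singly.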